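Bromo for Chloro on the Benzyl Ring of Triazole Ethers

The source may report more compounds than this note shows. Statements on the series, on what has been measured and on what is new or still open speak of the compounds shown alone.

Compound 1 `Clc1ccc(Cn2cc(COc3ccccc3)nn2)cc1` and compound 2 `Brc1ccc(Cn2cc(COc3ccccc3)nn2)cc1` share a core and differ at a single aromatic carbon. In an ADME assay on THP-1 cells (Homo sapiens) for inhibition, read by MTT assay, with a stated time of 48 h (on this read-out higher numbers stand for weaker inhibition of growth and lower numbers for stronger inhibition of growth), compound 1 gives 36.4 ug/mL and compound 2 gives 16.2 ug/mL; the step of a 2.2-fold lower number from compound 1 to compound 2 (0.35 log units; beyond the scatter) corresponds to bromo in place of chloro on an aromatic carbon. Compound 3 `Clc1ccc(Cn2cc(COc3c(Cl)cc(Cl)cc3Cl)nn2)cc1` carries a different core; how its core differs from that of compound 1 is not broken down here. In this assay compound 3 gives 25.1 ug/mL, within the scatter of both compound 1 and compound 2. Compound 4 `Clc1cc(Cl)c(OCc2cn(Cc3ccc(Br)cc3)nn2)c(Cl)c1` stands to compound 3 as compound 2 stands to compound 1: bromo in place of chloro on an aromatic carbon, at the same place on the ring. Because the step of a 2.2-fold lower number from compound 1 to compound 2 (0.35 log units; beyond the scatter) was measured for this very change, the step of a 2.2-fold lower number from compound 3 to compound 4 (0.34 log units; beyond the scatter) is expected to be of similar size, though one precedent gives little certainty. Compound 4 is therefore expected to give 11.5 ug/mL in this assay, between 6 ug/mL and 22 ug/mL.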

Compound 4, concentration for 50% growth inhibition: 58.7 ug/mL
For compound 4 the middle estimate is 5.1-fold (0.71 log units) below the measured one; the whole stated range lies below it.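

In this assay the same swap of 4-chlorobenzyl to 4-bromobenzyl gives a 2.3-fold higher number from compound 3 to compound 4 (0.37 log units; beyond the scatter) and so weakens inhibition of growth, whereas it strengthened inhibition on the core of compound 1. The change thus does not carry over from one core to the other with the same direction, and the two steps differ: the same change on two cores in this assay, a 2.2-fold lower number (0.35 log units; beyond the scatter) from compound 1 to compound 2 and a 2.3-fold higher number (0.37 log units; beyond the scatter) from compound 3 to compound 4, 5.3-fold (0.72 log units) apart, beyond the scatter of two such steps. This shows that the outcome of the swap depends on the core in these two pairs, but two pairs give no rule for other cores and do not show what causes the reversal.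

As far as these compounds go, it remains open which feature of the core of compound 3 turns the step around. Also open, from the compounds shown here alone, is how a fluoro, a methoxy or an amine in place of the halogen on the benzyl ring would read in this assay on either core.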